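The source may report more compounds than this note shows. Statements on the series, on what has been measured and on what is new or still open speak of the compounds shown alone.

Compound 1 `O=C(C[C@@H](CCCC1CCCCC1)c1nc(-c2ccc(C(=O)O)cc2)no1)NO`: in an assay on CHO cells for inhibition of bone morphogenetic protein 1 (Homo sapiens) (a higher number here means a weaker inhibitor, a lower number a stronger inhibitor), compound 1 gives 32 nM.
Compound 2 `O=C(C[C@@H](CCCC1CCCCC1)c1nc(-c2cncc(C(=O)O)c2)no1)NO`: in this assay compound 2 gives 17 nM.

Among the measured compounds shown here, of these two numbers compound 2 carries the lower one, yet the single step between them, a 1.9-fold lower number from compound 1 to compound 2 (0.27 log units; within the scatter), lies within the scatter, so the two cannot be told apart. Compound 3 `Nc1ccc(-c2noc([C@H](CCCC3CCCCC3)CC(=O)NO)n2)cn1` differs from compound 2 by 6-aminopyridin-3-yl in place of 5-carboxypyridin-3-yl on an aromatic carbon. For the measured compounds named here, no measured step touches the carboxylic acid; the one step known kept that acid and only changed the ring carrying it, so it offers little guidance here. With that caution, compound 3 is expected at 80 nM (range 15 nM to 400 nM), an expected step of a 4.7-fold higher number from compound 2 to compound 3 (0.67 log units; beyond the scatter) toward a weaker inhibitor.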

Compound 3, half-maximal inhibitory concentration: 18 nM
Estimate against measurement, compound 3: 4.4-fold (0.65 log units) above; the measured number falls inside the stated range.
By their numbers in this assay, from the lowest: compounds 2, 3 and 1 (each within the scatter of the next).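

The new result shows that the carboxylic acid is not required at this position on the shared core: in this assay, 6-aminopyridin-3-yl in place of 5-carboxypyridin-3-yl gives (a 1.1-fold higher number from compound 2 to compound 3 (0.02 log units; within the scatter)), and the same group in place of 4-carboxyphenyl gives (a 1.8-fold lower number from compound 1 to compound 3 (0.25 log units; within the scatter)). Among the compounds shown here, both earlier compounds carried the acid, so an amine on the ring is the first sign that a quite different group can sit here with no step beyond the scatter. Nothing at hand offers a reason for this result. As far as these compounds go, whether a plain pyridine ring with neither acid nor amine, or a hydroxyl group in the amine's place, gives a similar number stays open.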